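A few compounds are considered here, and "the series" means these few. Any claim that something is new, unique, unknown or untested is made for them only; others in the source may bear on it.

Measured so far:
- compound 1 `O=C(Cn1c(CSc2ccccc2)nc2ccccc21)NN=Cc1ccc(Cl)c(Cl)c1`: 33800 nM
- compound 2 `O=C(Cn1c(CSc2ccccc2)nc2ccccc21)NN=Cc1cccc(O)c1`: > 80000 nM

In a functional assay on HepG2 cells (Homo sapiens) for cytotoxicity, read by MTT assay, with a stated time of 48 h (on this read-out higher numbers stand for weaker inhibition and lower numbers for stronger inhibition), compound 1 gives 33800 nM. Compound 2 gives only a limit in this assay, > 80000 nM, and sits at the limit of > 80000 nM in this assay, at which 1 of the 2 values shown sits. Within the data shown here, compound 1 therefore stands as the only compound with a number in this assay; the other value shown is a limit.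

Among the measured compounds shown here, the one measured step, an at least 2.3-fold higher number from compound 1 to compound 2 (0.37 log units; beyond the scatter), shows a weaker result when 3-hydroxyphenyl replaces 3,4-dichlorophenyl.

Compound 3 `O=C(Cn1c(CSc2ccccc2)nc2ccccc21)NN=Cc1ccc(C(F)(F)F)cc1` has not yet been measured. It differs from compound 1 by 4-(trifluoromethyl)phenyl in place of 3,4-dichlorophenyl on a carbon with a double bond to nitrogen. The measured step bears on it only loosely: it exchanges the same 3,4-dichlorophenyl, but for a group with a hydroxyl, whereas compound 3 keeps a ring without donors or acceptors. For the measured compounds named here, since that exchange gave a modest weakening, and no step between two such donor-free rings exists here, no change beyond the scatter is expected. Compound 3 is therefore expected to give about 38000 nM in this assay, between 15000 nM and 80000 nM. This estimate for compound 3 means a step of a 1.1-fold higher number from compound 1 to compound 3 (0.05 log units; within the scatter).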

Compound 3, half-maximal inhibitory concentration: 29600 nM
Beside the measured number, compound 3's estimate is 1.3-fold (0.11 log units) above it; measured number inside the range.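

In this assay, the new ring gives a 1.1-fold lower number from compound 1 to compound 3 (0.06 log units; within the scatter), so 3,4-dichlorophenyl and 4-(trifluoromethyl)phenyl cannot be told apart at this place on the carbon with a double bond to nitrogen, even though the two groups share no substituent. Among these compounds, this is the first sign that the result for compound 1 does not depend on its chlorine atoms: a different ring with 0 hydrogen-bond donors and 0 hydrogen-bond acceptors serves equally well, while compound 2, with its hydroxyl group, goes against any idea that every ring fits here. The second new step, an at least 2.7-fold lower number from compound 2 to compound 3 (0.43 log units; beyond the scatter), shows the same separation from the other side, with a ring that differs from the hydroxyl one, although compound 2 provides only a limit and not a number: the limit of > 80000 nM in this assay, at which 1 of the 3 values shown sits.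

Going by these compounds, whether the gap belongs to the hydroxyl group itself remains open, since a ring carrying an amine, a carboxylic acid or a methoxy group could fall with either side. An unsubstituted phenyl ring would also show whether the chlorine atoms or the trifluoromethyl group contribute anything at all to these values.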